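Adding a chloro group to the core of compound 3

The compounds below may be only part of what the source reports. "The series", "measured", "known", "first", "only" and "open" are said of these compounds alone.

Measured compounds and their values:
Compound 1 `ClCc1ccc(Cn2cnc3nc(Cl)nc(Cl)c32)cc1` gives 3010 nM in a functional assay on MDA-MB-435 cells (Homo sapiens) for cytotoxicity, read by sulforhodamine B assay, with a stated time of 48 h; on this read-out lower numbers stand for stronger inhibition of growth and higher numbers for weaker inhibition of growth.
Compound 2 `ClCc1cccc(Cn2cnc3c(Cl)nc(Cl)nc32)c1` gives 3230 nM in this assay.
Compound 3 `ClCc1ccccc1Cn1cnc2ncnc(Cl)c21` gives 3800 nM in this assay.

Compound 3 has the highest of the three numbers, but its gaps to compound 2 and to compound 1 both lie within the usual scatter, so the three compounds cannot be told apart on these figures. Compound 4 `ClCc1ccccc1Cn1cnc2nc(Cl)nc(Cl)c21` has not yet been measured. It differs from compound 3 by chloro in place of hydrogen on an aromatic carbon. Going by the values given here, no step between two measured compounds shows the effect of this change alone. What the numbers do show is that compounds 1 and 2, whose cores carry this chloro group, sit within the scatter of compound 3, which lacks it. On that basis the step from compound 3 to compound 4 in this assay is expected to be small, a 1.2-fold lower number from compound 3 to compound 4 (0.07 log units; within the scatter), with no direction beyond the scatter. Compound 4 is therefore estimated at 3200 nM, with a range from 1500 nM to 6500 nM.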

Compound 4, concentration for total growth inhibition: 30900 nM
Beside the measured number, compound 4's estimate is 9.7-fold (0.98 log units) below it, outside the stated range (above it).
By their numbers in this assay, from the lowest: compounds 1, 2 and 3 (each within the scatter of the next); then compound 4.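

Going by these compounds alone, this is the first step here that isolates a single change, and it shows that the position on the six-membered aromatic ring, between two ring nitrogen atoms, is not indifferent to substitution: in this assay, chloro in place of hydrogen there gives an 8.1-fold higher number from compound 3 to compound 4 (0.91 log units; beyond the scatter), which means weaker inhibition of growth. The close agreement among the three earlier numbers had hidden this, since those compounds differ in more than one place and so could not reveal what this change does alone. No measurement shown here explains the loss.

Going by these compounds, what remains open is whether the loss is specific to chloro or would also appear with another group at this carbon, such as fluoro, methoxy or an amine. On these data alone, it is also open whether the same change would cost as much with the chloromethyl group elsewhere on the benzyl ring.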